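The source may hold more compounds than are shown below. What is called first, only, known or untested is meant among the compounds shown, and "the series" means these compounds.

Measured so far in a functional assay on Jurkat cells (Homo sapiens) for antiproliferative activity, read by MTT assay; on this read-out higher numbers stand for weaker inhibition and lower numbers for stronger inhibition:
- compound 1 `COc1cccc(/C=C2\CCc3cc(OC)c(OC)cc3C2=O)c1` gives 5000 nM
- compound 2 `COc1cc2c(cc1OC)C(=O)/C(=C/c1cccc(OC)c1OC)CC2` gives > 50000 nM (a limit of the assay, not a number)
- compound 3 `COc1cc(/C=C2\CCc3cc(OC)c(OC)cc3C2=O)cc(OC)c1` gives 5000 nM

In this assay compound 1 reads 5000 nM and compound 3 reads 5000 nM as well, so these two stand level. Compound 4 `COc1cc2c(cc1OC)C(=O)/C(=C/c1cc(OC)c(OC)c(OC)c1)CC2` differs from compound 3 by one change, (methoxy in place of hydrogen on an aromatic carbon), which is methoxy in place of hydrogen on an aromatic carbon. The new methoxy is ortho to two methoxy groups and para to a large group.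

Two measured steps are the same kind of change, made at other places. One gave no change at the digits printed from compound 1 to compound 3 (within the scatter) and the other gave an at least 10-fold higher number from compound 1 to compound 2 (1.00 log units; beyond the scatter), so this kind of change has done either nothing or clear harm. Compound 4 keeps both methoxy groups of compound 3, so the harmless step is taken as the main guide, and no change beyond the scatter is expected. The upper end of the range is left wide to allow for a loss like the larger step. The expected result is a 1.2-fold higher number from compound 3 to compound 4 (0.08 log units; within the scatter) as an estimate. Compound 4 is estimated at 6000 nM, with an expected range from 1500 nM to 30000 nM.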

Compound 4, half-maximal inhibitory concentration: > 50000 nM
Compound 4 gave a limit, no number; the forecaster's own chance of this, stated with the estimate: 15%; middle value at least 8.3-fold (0.92 log units) from the limit.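

In this assay, a methoxy that is ortho to two methoxy groups and para to a large group gives an at least 10-fold higher number from compound 3 to compound 4 (1.00 log units; beyond the scatter). Compound 4 reads > 50000 nM, which is a limit of the assay. Before this result, the change had one harmless case and one harmful case, so the new step shows that a harmless methoxy elsewhere on the ring does not make a further one safe here, and the change has now gone wrong on two cores: the same change on two cores in this assay, an at least 10-fold higher number (1.00 log units; beyond the scatter) from compound 1 to compound 2 and an at least 10-fold higher number (1.00 log units; beyond the scatter) from compound 3 to compound 4; the limit leaves it open whether they differ

From the compounds shown here alone, how much weaker compound 2 and compound 4 truly are, and how they rank against each other, stays unknown: the limit of > 50000 nM in this assay, at which 2 of the 4 values shown sit. Also open is whether a hydroxyl or a fluorine at this same place would keep the reading of compound 3, or would lose it as the methoxy does.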